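This account rests on a few compounds, and the source may have more. Where it says the series, first, only, none or still open, it means among the compounds named here.

Measured compounds:
compound 1 `Nc1nc(SCc2coc3ccccc3c2=O)n[nH]1` – > 25000 nM
compound 2 `Cc1cc(O)cc2oc(=O)cc(CSc3nc4ccccc4s3)c12` – > 25000 nM

In a functional assay on HeLa cells (Homo sapiens) for cytotoxicity, read by MTT assay, with a stated time of 72 h (on this read-out lower numbers stand for stronger inhibition and higher numbers for weaker inhibition), compound 1 gives > 25000 nM, which is a limit of the assay and not a number. Compound 2 likewise stops at a limit in this assay, at > 25000 nM. Both values sit at the limit of > 25000 nM in this assay, at which 2 of the 2 values shown sit, so compound 1 cannot be ranked against compound 2 beyond the fact that neither reaches a number. Compound 3 `Cc1nnc(SCc2coc3ccccc3c2=O)s1` differs from compound 1 by 5-methyl-1,3,4-thiadiazol-2-yl in place of 5-amino-1H-1,2,4-triazol-3-yl on a sulfur. Going by the values given here, no measured step exists to gauge such a change, so no shift beyond the scatter in this assay is expected. Compound 3 is therefore expected at 30000 nM, between 10000 nM and 100000 nM. The expected step is a step that the limit leaves unreadable from compound 1 to compound 3.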

Compound 3, half-maximal inhibitory concentration: 2300 nM
The estimate for compound 3 lay 13-fold (1.12 log units) above the measured number; measured number outside the range, below it.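

In this assay, the group on the sulfur can clearly move the read-out: 5-methyl-1,3,4-thiadiazol-2-yl in place of 5-amino-1H-1,2,4-triazol-3-yl gives an at least 10-fold lower number from compound 1 to compound 3 (1.03 log units; beyond the scatter), a step beyond the scatter. Compound 3 alone reaches a number instead of a limit: the limit of > 25000 nM in this assay, at which 2 of the 3 values shown sit. The two groups are alike in ring size but differ in their atoms and hydrogen-bond donors, and this one step cannot separate those differences.

As far as these compounds go, it remains open whether the ring or its methyl carries the step. Also open, from the compounds shown here alone, is what an amine or a longer chain in place of that methyl would give.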